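The compounds below may be only part of what the source reports. "The series", "measured", "known", "first", "only" and "open" are said of these compounds alone.

Compound 1 `COc1ccccc1Nc1nc(-c2cccc(F)c2)nc2ccc(F)cc12` and compound 2 `Fc1cccc(Nc2nc(-c3cccc(F)c3)nc3ccc(F)cc23)c1` have been measured; compound 3 `Fc1cccc(-c2nc(Nc3ccccc3Cl)c3cc(F)ccc3n2)c1` has not.

In a functional assay on U2OS cells (Homo sapiens) for cytotoxicity, read by MTT assay, with a stated time of 48 h (a higher number here means a weaker inhibitor, a lower number a stronger inhibitor), compound 1 gives > 50000 nM, which is a limit of the assay rather than a number. In this assay compound 2 gives 49600 nM. For the measured compounds named here, the value of compound 1 is a limit, so compound 2 supplies the only number in the set and stands as its single fixed point. The step of a number no higher from compound 1 to compound 2 (the limit leaves the size open) is known only through (the limit of > 50000 nM in this assay, at which 1 of the 2 values shown sits), so its size cannot be read.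

Compound 3 differs from compound 2 by 2-chlorophenyl in place of 3-fluorophenyl on a nitrogen on an aromatic ring. Going by the values given here, the one measured step swapped a group at the same place and gave no readable size, so it offers no ground to expect a change beyond the usual scatter for this new swap. The step of a 1.0-fold higher number from compound 2 to compound 3 (0.00 log units; within the scatter) is therefore expected to stay within that scatter. Compound 3 is estimated at 50000 nM, with a range from 20000 nM to 120000 nM.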

Compound 3, half-maximal inhibitory concentration: > 50000 nM
Compound 3 ended at the assay's limit; the forecaster's own chance of this, stated with the estimate: 50%; the middle value sits exactly at the limit.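

In this assay compound 3 gives > 50000 nM, which is a limit of the assay and not a number. For the compounds shown here, putting 2-chlorophenyl in place of 3-fluorophenyl on the nitrogen gives a number no lower from compound 2 to compound 3 (the limit leaves the size open) and thus a second group at this place, after the 2-methoxyphenyl of compound 1, that yields no readable number, and compound 2 remains the only compound with one. This step and the step from compound 1 to compound 3 cannot be read, because each has a limit at one or both ends: the limit of > 50000 nM in this assay, at which 2 of the 3 values shown sit.

On these data alone, the true numbers of compound 1 and compound 3 stay open, so their groups cannot be ranked against each other or against 3-fluorophenyl. Also open, as far as these compounds go, is whether a phenyl ring carrying an amine or a carboxylic acid at this place would give a clearly lower number.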